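The source may hold more compounds than are shown below. What is called first, only, known or untested is meant among the compounds shown, and "the series" means these compounds.

In an ADME assay on MRC5 cells (Homo sapiens) for inhibition, read by MTT assay, with a stated time of 72 h (on this read-out lower numbers stand for stronger inhibition and higher numbers for weaker inhibition), compound 1 `O=C(OCCCCCCO)OCCc1ccc(OCc2ccccc2)c(OCc2ccccc2)c1` gives > 50000 nM, which is a limit of the assay and not a number. Compound 2 `O=C(OCCCCO)OCCc1ccc(O)c(O)c1` has no number to stand on, as its result reads "not determined" (no result reported). The next compound to be tested, compound 3 `CCCCCCOC(=O)OCCc1ccc(O)c(O)c1`, is a close relative of compound 2. The difference is ethyl in place of hydroxy on a saturated chain carbon, four bonds along the chain from an oxygen next to a carbonyl group, which means ethyl in place of hydroxy on a saturated chain carbon, four bonds along the chain from an oxygen next to a carbonyl group. Within the data shown here, no measured step between these compounds exists to serve as a guide, so any expectation here is tentative. A modest step toward stronger inhibition in this assay is expected, with compound 3 staying close to the top of the measurable range. Compound 3 is estimated at 40000 nM, with an expected range of 12000 nM to 100000 nM.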

Compound 3, half-maximal inhibitory concentration: 11200 nM
For compound 3 the middle estimate is 3.6-fold (0.55 log units) above the measured one; the whole stated range lies above it.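

No step can be read from these results: compound 2 has no reported result in this assay, so compound 3 has no measured partner to be set against. On these data alone, what ethyl in place of hydroxy does to inhibition in this assay remains open.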